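Methyl in Place of Methoxy in a Growth Inhibitor

A few compounds are considered here, and "the series" means these few. Any claim that something is new, unique, unknown or untested is made for them only; others in the source may bear on it.

In a functional assay on A549 cells (Homo sapiens) for inhibition, read by CCK-8 assay, with a stated time of 72 h, tested at 10 uM (on this read-out higher numbers stand for more inhibition of growth at the one concentration tested and lower numbers for less inhibition of growth), compound 1 (`COc1ccc(NC(=O)C2(C(=O)Nc3ccc(Nc4ncc5cc(C(=O)N(C)C)n(C6CCCC6)c5n4)cc3)CC2)cc1`) gives 78.5% and stands highest of the two measured compounds. A smaller molecule without the core of compound 1, compound 2 (`Nc1ccc(NC(=O)C2(C(=O)Nc3ccc(F)cc3)CC2)cc1F`) gives 14.6% and lies beyond the scatter from compound 1. Compound 3 (`Cc1ccc(NC(=O)C2(C(=O)Nc3ccc(Nc4ncc5cc(C(=O)N(C)C)n(C6CCCC6)c5n4)cc3)CC2)cc1`) keeps that core and changes in one place, with methyl in place of methoxy on an aromatic carbon, para to a large group (methyl in place of methoxy on an aromatic carbon). For the measured compounds named here, no measured pair shows what this change does, so compound 1 at 78.5% is the only close reference for the expectation. The step of a number 3.5 percentage points lower from compound 1 to compound 3 (within the scatter) is expected to be small, slightly downward if anything, and within the scatter. For compound 3 the estimated value in this assay is 75% with an expected range from 60% to 88% on repeated measurement.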

Compound 3, percent growth inhibition at one concentration: 90.6%
The estimate for compound 3 lay 15.6 percentage points below the measured number; the whole stated range lies below it.
By their numbers in this assay, from the lowest: compound 2; then compound 1; then compound 3.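

In this assay, methyl in place of methoxy on this aromatic carbon, para to a large group, gives a number 12.1 percentage points higher from compound 1 to compound 3 (beyond the scatter) on the shared core. The oxygen of the methoxy group, and the hydrogen-bond acceptor it counts for, are therefore not required here for growth inhibition at the one concentration tested. Nothing at hand explains this step, which rests on a single pair of compounds.

Going by these compounds, what an amine, a chlorine atom or a longer chain such as ethyl would do on this aromatic carbon remains open, as does whether plain hydrogen there would match methyl or fall back towards methoxy. Also open, on these data alone, is whether the same change would give a similar step on a different core, or at any other concentration.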